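Lengthening the Amidine Side Chain of Compound 2

The compounds below may be only part of what the source reports. "The series", "measured", "known", "first", "only" and "open" are said of these compounds alone.

Compound 2 `COCC(=N)NCCC[C@H](N)C(=O)O` gives 73000 nM in an assay on cells for inhibition of N(G),N(G)-dimethylarginine dimethylaminohydrolase 1 (Homo sapiens), with a stated time of 30 min (on this read-out lower numbers stand for stronger inhibition and higher numbers for weaker inhibition), the lowest of the three numbers available here. Compound 3 `COCC(=N)NCCCCN` gives 983000 nM in this assay, and the difference between the two, hydrogen in place of carboxy, reads a 13-fold higher number from compound 2 to compound 3 (1.13 log units; beyond the scatter). Within the data shown here, compound 1 `CCCCCNC(=N)NCCOC` gives 2820000 nM in this assay, a number far above that of compound 2, though the two structures differ in more than one place and no single step links them. Compound 4 `COCCC(=N)NCCC[C@H](N)C(=O)O` differs from compound 2 by methoxymethyl in place of methoxy on a saturated chain carbon bound to a carbon with a double bond to nitrogen. Among the measured compounds shown here, neither measured comparison bears directly on this change: the only single step concerns the carboxy group, not the chain on the amidine carbon. With no guidance on direction, the expectation for the step is a modest one, a 2.1-fold higher number from compound 2 to compound 4 (0.31 log units; beyond the scatter), perhaps not beyond the scatter. Compound 4 is therefore estimated to give 150000 nM in this assay, with a range from 40000 nM to 600000 nM.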

Compound 4, inhibition constant: 9000 nM
Estimate against measurement, compound 4: 17-fold (1.22 log units) above, outside the stated range (below it).
By their numbers in this assay, from the lowest: compound 4; then compound 2; then compound 3; then compound 1.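

In this assay, the change from methoxy to methoxymethyl on a saturated chain carbon bound to a carbon with a double bond to nitrogen gives an 8.1-fold lower number from compound 2 to compound 4 (0.91 log units; beyond the scatter). This shows that the position responds to the longer group and that the number falls, which the earlier step, a 13-fold higher number from compound 2 to compound 3 (1.13 log units; beyond the scatter), could not show because it concerned the carboxy group elsewhere in the molecule. No measurement here accounts for why the longer group gives the lower number.

The compounds shown leave open whether a still longer chain at this position, such as a 3-methoxypropyl group, would lower the number further or raise it again. They also leave open whether the oxygen matters, which a plain propyl chain in place of methoxymethyl would test.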